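Chloro on the pyridone ring of compound 2

The compounds below may be only part of what the source reports. "The series", "measured", "known", "first", "only" and "open" are said of these compounds alone.

Of the compounds shown here, three sharing one core have been measured in an assay on PBMC cells for antagonist activity at Toll-like receptor 8 (Homo sapiens), read by HTRF, with stated times of 30 min and 20 h; on this read-out lower numbers stand for stronger inhibition and higher numbers for weaker inhibition. Compound 1 `Cn1cc(-c2ccc3nc(N4CCN(C5CCC5)CC4)ncc3c2)ccc1=O` gives 91 nM in this assay. Compound 2 `Cc1cc(-c2ccc(=O)n(C)c2)cc2cn(C3CCNCC3)nc12` gives 320 nM, the highest of the three numbers; the nearest is compound 1, and the furthest is compound 3 `Cc1cc(=O)n(C)cc1-c1cc(C)c2nn(C3CCNCC3)cc2c1`, which gives 76 nM. Going by the values given here, the one step between measured compounds that differ in a single place is a 4.2-fold lower number from compound 2 to compound 3 (0.62 log units; beyond the scatter), a methyl in place of hydrogen on an aromatic carbon of the same six-membered ring.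

Compound 4 `Cc1cc(-c2ccc(=O)n(C)c2Cl)cc2cn(C3CCNCC3)nc12` has not yet been measured. It differs from compound 2 by chloro in place of hydrogen on an aromatic carbon, that is, a chloro in place of hydrogen on an aromatic carbon next to the ring nitrogen, ortho to a large group and ortho to a methyl group. Among the compounds with values here, the only step that bears on it is the one from compound 2 to compound 3, where a small group entering the same ring lowered the number beyond the scatter. The change here is at a different carbon, so a smaller gain is expected, a 2.0-fold lower number from compound 2 to compound 4 (0.30 log units; within the scatter). Compound 4 is therefore estimated at 160 nM in this assay, with a range from 60 nM to 450 nM.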

Compound 4, half-maximal inhibitory concentration: 30 nM
Estimate against measurement, compound 4: 5.3-fold (0.73 log units) above, and the stated range ends above it.
By their numbers in this assay, from the lowest: compound 4; then compounds 3 and 1 (each within the scatter of the next); then compound 2.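

In this assay, chloro in place of hydrogen on the aromatic carbon next to the ring nitrogen gives an 11-fold lower number from compound 2 to compound 4 (1.03 log units; beyond the scatter), a large step, whereas the methyl of the earlier pair gave the modest 4.2-fold lower number from compound 2 to compound 3 (0.62 log units; beyond the scatter). This shows that the carbon ortho to a large group and ortho to a methyl group is a place where a single heavy atom can change the number strongly, although the two steps differ in both the group and the carbon. Nothing measured here explains the size of this step.

As far as these compounds go, it remains open whether the gain belongs to chloro itself or would also appear with fluoro, methyl or methoxy on this carbon. The compounds shown also leave open whether chloro and the methyl of compound 3, placed together on one ring, would lower the number further.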